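Swapping a nitrile for fluorine on the pyridine arm

The compounds below may be only part of what the source reports. "The series", "measured", "known", "first", "only" and "open" are said of these compounds alone.

Of the compounds shown here, three have been measured in an in vitro functional assay on 1321-N1 cells for antagonist activity at transient receptor potential cation channel subfamily V member 1 (Homo sapiens), read by FLIPR and calcium flux; on this read-out lower numbers stand for stronger inhibition and higher numbers for weaker inhibition. Compound 1, with the structure `CC(C)(C)c1ccc(NC(=O)c2ccc(-c3ccccn3)cc2)cc1`, gives 42 nM. Compound 2, with the structure `O=C(Nc1ccc(C(F)(F)F)nc1)C1=CCN(c2ncccc2C(F)(F)F)CC1`, gives 42 nM. Compound 3, with the structure `CC(C)(C)c1ccc(NC(=O)C2=CCN(c3ncccc3C#N)CC2)cc1`, gives 78 nM, a number that sits within the usual scatter of both compound 1 and compound 2, so the three cannot be told apart on these figures.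

Compound 4, with the structure `CC(C)(C)c1ccc(NC(=O)C2=CCN(c3ncccc3F)CC2)cc1`, has not yet been measured in this assay. It differs from compound 3 in one place: fluoro in place of cyano on an aromatic carbon. Among the measured compounds shown here, no pair of measured compounds shows the effect of this exchange, so there is no measured step to lean on.

Given that, the change from compound 3 to compound 4 is expected to produce a step of a 1.2-fold higher number from compound 3 to compound 4 (0.06 log units; within the scatter), which is not beyond the scatter. Compound 4 is therefore estimated to give 90 nM in this assay, with a likely range from 35 nM to 250 nM.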

Compound 4, half-maximal inhibitory concentration: 19 nM
Compound 4: the middle estimate sits 4.7-fold (0.68 log units) above what was measured; the measured number lies below the stated range.
By their numbers in this assay, from the lowest: compound 4; then compounds 1, 2 and 3 (each within the scatter of the next).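

In this assay, among the compounds shown here, the exchange of fluoro for cyano on this aromatic carbon gives a 4.1-fold lower number from compound 3 to compound 4 (0.61 log units; beyond the scatter) and is the first single change that can be read, since the earlier compounds differed in more than one place and their values could not be told apart. For this pair, the nitrile is not needed for inhibition: with a single fluorine in its place, the number falls rather than rises. No measurement shown here gives a reason for the step.

As far as these compounds go, whether a chloro, methyl or methoxy group on this same carbon would give a lower or higher number than fluoro remains open. It is also unknown whether the same exchange would produce a step of similar size on a different core.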